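A few compounds are considered here, and "the series" means these few. Any claim that something is new, unique, unknown or untested is made for them only; others in the source may bear on it.

Compound 1 `COc1cc(-c2ccnc3cc(-c4ccc(C)cc4)nn23)cc(OC)c1OC` gives 47 nM in a functional assay on MCF7 cells (Homo sapiens) for inhibition, read by CCK-8 assay, with a stated time of 48 h; on this read-out higher numbers stand for weaker inhibition and lower numbers for stronger inhibition. Compound 2 `COc1ccc(-c2cc3nccc(-c4cc(OC)c(OC)c(OC)c4)n3n2)cc1F` gives 183 nM. Compound 3 `COc1cc(-c2ccnc3cc(-c4ccc(F)cc4)nn23)cc(OC)c1OC` gives 1280 nM.

Compound 3 has the highest number of the three: its nearest neighbour is compound 2 (a 7.0-fold higher number from compound 2 to compound 3 (0.84 log units; beyond the scatter)), the furthest is compound 1 (a 27-fold higher number from compound 1 to compound 3 (1.44 log units; beyond the scatter)). Compound 4 `COc1cc(-c2ccnc3cc(-c4cccc(C)c4)nn23)cc(OC)c1OC` differs from compound 3 in one place: 3-methylphenyl in place of 4-fluorophenyl on an aromatic carbon. Among the compounds with values here, two measured steps bear on this. Exchanging fluoro for methyl on this ring was large (a 27-fold higher number from compound 1 to compound 3 (1.44 log units; beyond the scatter)), and replacing 4-fluorophenyl by another substituted phenyl was modest (a 7.0-fold higher number from compound 2 to compound 3 (0.84 log units; beyond the scatter)). Within the data shown here, no measured compound carries 3-methylphenyl, so a step toward compound 1 is expected, but smaller than the full reverse of that step: an 8.0-fold lower number from compound 3 to compound 4 (0.90 log units; beyond the scatter) is expected. Compound 4 is estimated at 160 nM, with a range of 40 nM to 650 nM.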

Compound 4, half-maximal inhibitory concentration: 1080 nM
For compound 4 the middle estimate is 6.8-fold (0.83 log units) below the measured one; the measured number lies above the stated range.
By their numbers in this assay, from the lowest: compound 1; then compound 2; then compounds 4 and 3 (each within the scatter of the next).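

With a 23-fold higher number from compound 1 to compound 4 (1.36 log units; beyond the scatter), the methyl group alone does not carry the low number of compound 1: on this aromatic carbon it holds for 4-methylphenyl and is lost with 3-methylphenyl. With a 1.2-fold lower number from compound 3 to compound 4 (0.07 log units; within the scatter), 3-methylphenyl cannot be told apart from 4-fluorophenyl here, while a 5.9-fold higher number from compound 2 to compound 4 (0.77 log units; beyond the scatter) leaves 3-fluoro-4-methoxyphenyl clearly the better of these two groups. No measurement offered here explains these differences. Still open, as far as these compounds go, is whether a longer chain, as in 4-ethylphenyl, or an amine, as in 4-aminophenyl, would keep the number of compound 1.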